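Substituent on the phenyl ring: compound 3 to compound 4

The source may hold more compounds than are shown below. What is called first, only, known or untested is meant among the compounds shown, and "the series" means these compounds.

Compound 3 `O=C1C2=C(C(=O)c3ncccc31)C1(CS2)NC(=O)N(c2ccccc2)C1=O` carries an unsubstituted phenyl on the shared core. For the measured compounds named here, in a functional assay on CCRF-SB cells (Homo sapiens) for antiproliferative activity, read by MTT assay, with a stated time of 96 h (a higher number here means a weaker inhibitor, a lower number a stronger inhibitor), compound 3 gives 30 nM, the highest number of the three measured so far. Compound 1 `CN(C)c1ccc(N2C(=O)NC3(CSC4=C3C(=O)c3ncccc3C4=O)C2=O)cc1` gives 1 nM and compound 2 `O=C1C2=C(C(=O)c3ncccc31)C1(CS2)NC(=O)N(c2ccc([N+](=O)[O-])cc2)C1=O` gives 2 nM; the pair differ only by a 2.0-fold higher number from compound 1 to compound 2 (0.30 log units; within the scatter), so compound 1 and compound 2 are not ordered against each other, while compound 3 sits well apart from both.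

The next compound, compound 4 `CCCCc1ccc(N2C(=O)NC3(CSC4=C3C(=O)c3ncccc3C4=O)C2=O)cc1`, differs from compound 3 by butyl in place of hydrogen on an aromatic carbon.

Going by the values given here, two measured steps bear on this change, both leading out of a substituted ring into the bare phenyl of compound 3: a 30-fold higher number from compound 1 to compound 3 (1.48 log units; beyond the scatter) and a 15-fold higher number from compound 2 to compound 3 (1.18 log units; beyond the scatter). Read in the reverse sense, each time a group was present on the aromatic carbon of the six-membered ring of carbon only, the number in this assay was far lower than for the unsubstituted compound 3. Butyl is a different kind of group from either dimethylamino or nitro, so the size of its effect is open, but the direction in the two known steps was the same.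

For compound 4 the expectation is therefore a lower number than compound 3, by an estimated 3.8-fold lower number from compound 3 to compound 4 (0.57 log units; beyond the scatter). Compound 4 is estimated at 8 nM, with a range from 2 nM to 40 nM.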

Compound 4, half-maximal inhibitory concentration: 190 nM
Compound 4: the middle estimate sits 24-fold (1.38 log units) below what was measured, outside the stated range (above it).
By their numbers in this assay, from the lowest: compounds 1 and 2 (each within the scatter of the next); then compound 3; then compound 4.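

In this assay, a group on this aromatic carbon does not by itself lower the number: butyl gives a 6.3-fold higher number from compound 3 to compound 4 (0.80 log units; beyond the scatter), the opposite direction to the steps from dimethylamino and nitro into the bare phenyl. The gaps to the two substituted compounds are wider still, with a 95-fold higher number from compound 2 to compound 4 (1.98 log units; beyond the scatter) and a 190-fold higher number from compound 1 to compound 4 (2.28 log units; beyond the scatter), so across these four compounds the identity of the group matters, not just its presence, and compound 4 sits above the unsubstituted compound 3 rather than with compound 1 and compound 2. Nothing measured here accounts for the rise with butyl over the bare phenyl.

Open, as far as these compounds go, is whether methyl, ethyl or a longer chain such as hexyl would follow butyl upward, or whether the number depends on chain length at all, and whether a primary amine or a carboxylic acid on the same aromatic carbon would fall with dimethylamino and nitro. Also open, from the compounds shown here alone, is whether the rise with butyl carries over to cell lines other than this one.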